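The source may report more compounds than this note shows. Statements on the series, on what has been measured and on what is new or still open speak of the compounds shown alone.

Measured compounds in a functional assay on HEL cells (Homo sapiens), read by microscopy; on this read-out lower numbers stand for higher toxicity in this test and higher numbers for lower toxicity in this test:

Compound 1 `CCCCc1cc2cn(COCCO)c(=O)nc2o1`: > 400000 nM, a limit of the assay.
Compound 2 `CCCCCCCCCCCc1cc2cn(COCCO)c(=O)nc2o1`: 80000 nM.
Compound 3 `CCCCC#Cc1cc2cn(COCCO)c(=O)nc2o1`: > 100000 nM, a limit of the assay.

Going by the values given here, compound 3 stands at a limit in this assay, so its place among the three can only be bracketed: compound 2 is the one value shown as a number, and the other two sit at limits (the limit of > 100000 nM in this assay, at which 1 of the 3 values shown sits, and (the limit of > 400000 nM in this assay, at which 1 of the 3 values shown sits)).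

The step to compound 4 `CCCCCCc1cc2cn(COCCO)c(=O)nc2o1` is hexyl in place of hex-1-yn-1-yl on an aromatic carbon. Among the compounds with values here, no measured step changes an alkyne into a saturated chain at the same length. The step that bears most is an at least 5.0-fold lower number from compound 1 to compound 2 (0.69 log units; beyond the scatter), which shows a longer saturated chain lowering the number; the step that the two limits leave unreadable from compound 1 to compound 3 is unreadable from its two limits. Hexyl lies between butyl and undecyl in length, so in this assay a small step from compound 3, if any, is expected: a step that the limit leaves unreadable from compound 3 to compound 4, most probably ending again at a limit. Compound 4 is therefore estimated at 200000 nM, within 60000 nM to 600000 nM.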

Compound 4, minimum cytotoxic concentration: >= 400000 nM
Compound 4: only a limit was reported; the forecaster's own chance of this, stated with the estimate: 70%; middle value at least 2.0-fold (0.30 log units) from the limit.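

In this assay compound 4 gives >= 400000 nM, which is a limit of the assay: the limit of >= 400000 nM in this assay, at which 1 of the 4 values shown sits.

On this aromatic carbon next to the ring oxygen, the hexyl chain does not carry the lower number seen with the undecyl chain, the shortening giving an at least 5.0-fold higher number from compound 2 to compound 4 (0.69 log units; beyond the scatter); among the saturated chains shown, a number below the limits therefore appears only with undecyl. The steps to compound 4 from compound 1 and from compound 3 cannot be read, so neither the change from butyl to hexyl nor the loss of the triple bond has a measurable size here.

Open, going by these compounds, is the chain length between hexyl and undecyl at which the number starts to fall, as an octyl or decyl chain would show. Also open, on these data alone, is whether a dodecyl chain, or a chain carrying an amine, would shift the number further.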